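This account rests on a few compounds, and the source may have more. Where it says the series, first, only, none or still open, it means among the compounds named here.

Of the compounds shown here, three sharing one core have been tested in a functional assay on HEK293 cells for agonist activity at G-protein coupled receptor 39 (Homo sapiens), read by scintillation proximity assay and inositol phosphate accumulation, with a stated time of 75 min; on this read-out lower numbers stand for an effect already at smaller amounts and higher numbers for an effect only at larger amounts of compound. Compound 1 `Cc1nn(-c2ncnc3nc[nH]c23)c2c1C(OCc1ccc(Cl)cc1Cl)CC(=O)N2` gives 243 nM. Compound 2 `Cc1cc(C)n(CCOC2CC(=O)Nc3c2c(C)nn3-c2ncnc3nc[nH]c23)n1` gives 2000 nM. Compound 3 `Cc1nn(-c2ncnc3nc[nH]c23)c2c1C(OCc1ccc(F)cc1)CC(=O)N2` gives 126 nM, the lowest of the three numbers, though its gap to compound 1 lies within the scatter, so the two cannot be ranked against each other; only compound 2 stands clearly apart.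

Compound 4 `Cc1nn(-c2ncnc3nc[nH]c23)c2c1C(OCc1cc(F)cc3c1OCOC3)CC(=O)N2` has not yet been measured. Compared with compound 3 the change is a group of 11 heavy atoms (8 carbon, 2 oxygen, 1 fluorine; one six-membered non-aromatic ring with 2 hetero atoms, one six-membered aromatic ring of carbon only) in place of a group of 7 heavy atoms (6 carbon, 1 fluorine; one six-membered aromatic ring of carbon only), on a saturated chain carbon bound to an oxygen on a saturated carbon. Two measured steps at this same position bear on it. Swapping one aromatic ring for another, a 1.9-fold lower number from compound 1 to compound 3 (0.29 log units; within the scatter), stayed within the scatter. Replacing a (3,5-dimethyl-1H-pyrazol-1-yl)methyl group with an aromatic ring, a 16-fold lower number from compound 2 to compound 3 (1.20 log units; beyond the scatter), was a large move, while the reverse, an 8.2-fold higher number from compound 1 to compound 2 (0.92 log units; beyond the scatter), went the other way. Among the measured compounds shown here, compound 4 keeps a six-membered aromatic ring of carbon only bearing a fluorine, and adds a fused non-aromatic ring; the nearest precedent is the aryl-to-aryl swap, which did not move the number beyond the scatter.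

The step from compound 3 to compound 4 is therefore expected to be small, a 1.2-fold higher number from compound 3 to compound 4 (0.08 log units; within the scatter), in either direction. Compound 4 is estimated at 150 nM, within a range from 50 nM to 500 nM.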

Compound 4, half-maximal effective concentration: 30 nM
Beside the measured number, compound 4's estimate is 5.0-fold (0.70 log units) above it; the measured number lies below the stated range.
By their numbers in this assay, from the lowest: compound 4; then compounds 3 and 1 (each within the scatter of the next); then compound 2.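

In this assay the step of a 4.2-fold lower number from compound 3 to compound 4 (0.62 log units; beyond the scatter) lies beyond the scatter, which the earlier swap of one aromatic group for another did not, so this position can respond to a change that keeps a fluorine-bearing aromatic ring and adds a six-membered non-aromatic ring with 2 hetero atoms. The same group also gives an 8.1-fold lower number from compound 1 to compound 4 (0.91 log units; beyond the scatter) and, against the (3,5-dimethyl-1H-pyrazol-1-yl)methyl group, a 67-fold lower number from compound 2 to compound 4 (1.82 log units; beyond the scatter) as its largest step, so all three steps to compound 4 lie beyond the scatter and compound 4 has the lowest number of the four. Nothing given here explains why this larger group goes with a lower number.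

A single compound cannot show whether the lower number depends on the added ring as a whole, on its two oxygens, or on how it combines with the fluorine, since these parts enter together. From the compounds shown here alone, it also remains open how this position would respond to an aromatic ring carrying an amine or a carboxylic acid, or to a longer chain between the oxygen and the ring.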